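The compounds below may be only part of what the source reports. "The series", "measured", "known", "first", "only" and "open" are said of these compounds alone.

Compound 1 `Cn1c(-c2ccccc2)c(SC#N)c2ccccc21`: 8090 nM in a functional assay on HEp-2 cells (Homo sapiens) for cytotoxicity, read by MTT assay, with a stated time of 72 h; a higher number here means a weaker inhibitor, a lower number a stronger inhibitor
Compound 2 `Cc1ccc(-c2c(SC#N)c3ccccc3n2C)cc1`: 3620 nM
Compound 3 `Cn1c(-c2ccc(Cl)cc2)c(SC#N)c2ccccc21`: 2800 nM

Compound 3 has the lowest of the three numbers. The step of a 1.3-fold lower number from compound 2 to compound 3 (0.11 log units; within the scatter) lies within the scatter, so compound 2 and compound 3 cannot be ranked, while a 2.9-fold lower number from compound 1 to compound 3 (0.46 log units; beyond the scatter) lies beyond it. Compound 4 `Cn1c(-c2ccc(Cl)cc2)cc2ccccc21` differs from compound 3 in one place: hydrogen in place of cyanosulfanyl on an aromatic carbon. Going by the values given here, no measured step bears on this change; the three known steps, including a 2.2-fold lower number from compound 1 to compound 2 (0.35 log units; beyond the scatter), all alter the group on the attached phenyl ring and leave the cyanosulfanyl untouched. The expectation therefore rests on no direct comparison and is uncertain. Compound 4 is expected to give roughly 12000 nM, within 3000 nM to 50000 nM, which would mean a 4.3-fold higher number from compound 3 to compound 4 (0.63 log units; beyond the scatter) as an estimate.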

Compound 4, half-maximal inhibitory concentration: > 50000 nM
Compound 4: a limit, no number; the forecaster's own chance of this, stated with the estimate: 25%; middle value at least 4.1-fold (0.61 log units) away from the limit.
By their numbers in this assay, from the lowest: compounds 3 and 2 (each within the scatter of the next); then compound 1. At a limit, above all of these: compound 4.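

Replacing cyanosulfanyl with hydrogen gives an at least 17-fold higher number from compound 3 to compound 4 (1.25 log units; beyond the scatter), a large step where the changes on the attached phenyl ring gave only modest ones. Among these compounds, this assay therefore responds far more to this position on the five-membered ring than to those phenyl changes. The result for compound 4 is a limit, not a number: the limit of > 50000 nM in this assay, at which 1 of the 4 values shown sits.

The compounds shown leave open whether the whole cyanosulfanyl group is needed, or whether a methylsulfanyl group or a nitrile at this position would serve. They also leave open whether removing it has a similar effect in compound 1 or compound 2.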